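Series notes: cytotoxicity step from compound 2 to compound 4

This account rests on a few compounds, and the source may have more. Where it says the series, first, only, none or still open, it means among the compounds named here.

Measured compounds, with the value each gives in an ADME assay on KB cells (Homo sapiens) for cytotoxicity, read by MTT assay, with a stated time of 44 h; on this read-out higher numbers stand for weaker inhibition and lower numbers for stronger inhibition:
- compound 1 `CCN(CC)C(=S)N/N=C\c1c[nH]c2ccccc12`: > 100000 nM, a limit of the assay.
- compound 2 `CCCNC(=S)N/N=C\c1c[nH]c2ccccc12`: > 100000 nM, a limit of the assay.
- compound 3 `Cc1ccccc1NC(=S)N/N=C\c1c[nH]c2ccccc12`: > 100000 nM, a limit of the assay.

Compound 2 stands at the limit of this assay, and no number is known for it. The two steps that reach it, from compound 1 to compound 2 a step that the two limits leave unreadable from compound 1 to compound 2 and from compound 2 to compound 3 a step that the two limits leave unreadable from compound 2 to compound 3, join two limits and give no readable size; the limit of > 100000 nM in this assay, at which 3 of the 3 values shown sit, is all the evidence this set holds.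

Compound 4 `S=C(NCc1ccccc1Cl)N/N=C\c1c[nH]c2ccccc12` differs from compound 2 by 2-chlorophenyl in place of ethyl on a saturated chain carbon bound to an amide-type nitrogen. The step from compound 2 to compound 3 is the nearest measured change, an aryl group entering where a chain stood, and it stayed at the limit; the step from compound 1 to compound 2 also stayed at the limit. For the measured compounds named here, there is no measured step of readable size to set an expectation from, so no step beyond the scatter is expected in this assay for compound 4, and the estimated step from compound 2 to compound 4 is a number no higher from compound 2 to compound 4 (the limit leaves the size open). For compound 4 the expected value in this assay is 100000 nM, within 40000 nM to 250000 nM, most likely reported as a limit again.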

Compound 4, half-maximal inhibitory concentration: > 100000 nM
Compound 4 was reported as a limit; the forecaster's own chance of this, stated with the estimate: 80%; the middle value lies on the limit itself.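

In this assay compound 4 gives > 100000 nM, a limit of the assay. For the compounds shown here, compound 2 also stands at a limit, so no step between compound 2 and compound 4 can be read, and the series offers only this: the limit of > 100000 nM in this assay, at which 4 of the 4 values shown sit. The compounds shown leave open what number any of them would carry, and whether 2-chlorophenyl in place of ethyl changes anything in this assay.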